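The compounds below may be only part of what the source reports. "The series", "measured", "known", "first", "only" and "open" are said of these compounds alone.

Compound 1 `COc1cc2c(cc1OC)CN(c1ccc(C=O)cc1)CC2`: 61%
Compound 2 `COc1cc2c(cc1OC)CN(c1ccccn1)CC2`: 70.8%

These two numbers come from an ADME assay on microsomes from liver (Homo sapiens) for metabolic stability, read by LC-MS, with a stated time of 10 min, tested at 500 uM; on this read-out lower numbers stand for a less stable compound and higher numbers for a more stable compound. Compound 1 gives 61% and compound 2 gives 70.8%. For the measured compounds named here, the gap between them lies within the usual scatter, so compound 1 stands level with the only other measured compound, and the two cannot be told apart.

Compound 3 `COc1cc2c(cc1OC)CN(c1ccc(F)cc1)CC2` keeps the shared core of compound 1 and alters one group, with fluoro in place of formyl on an aromatic carbon, para to a large group: fluoro in place of formyl on an aromatic carbon.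

Going by the values given here, no pair of measured compounds differs in just one place, so nothing shows directly what this kind of swap does. The data offer only a rough frame: compound 1 at 61% and compound 2 at 70.8% sit close together despite their different groups. On that thin basis, no change beyond the scatter is expected. The expected step is a number 7 percentage points higher from compound 1 to compound 3 (within the scatter), a small one that would stay within the scatter. For compound 3 the estimate is 68%, with an expected range from 50% to 85%.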

Compound 3, percent of the compound remaining in the Homo sapiens assay: 56.8%
Compound 3: middle estimate off by 11.2 percentage points, on the high side; the measured number falls inside the stated range.
By their numbers in the Homo sapiens assay, from the lowest: compounds 3, 1 and 2 (each within the scatter of the next, the first and the last beyond it).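

For the compounds shown here, in the Homo sapiens assay, this is the first direct reading of a single swap at this position, fluoro in place of formyl on an aromatic carbon, para to a large group, and the step is a number 4.2 percentage points lower from compound 1 to compound 3 (within the scatter), so the two compounds cannot be told apart on stability. The larger group on the amine nitrogen in a ring matters more in the Homo sapiens assay, where 4-fluorophenyl in place of pyridin-2-yl gives a number 14 percentage points lower from compound 2 to compound 3 (beyond the scatter), a modest but real step. In a physicochemical assay for solubility, read by LC-MS, in phosphate buffer, with a stated time of 20 min, at pH 7.0, tested at 100 uM (on this read-out lower numbers stand for lower solubility and higher numbers for higher solubility), compound 1 gives 6600 nM and compound 3 gives 20300 nM. The swap of formyl for fluoro is not silent everywhere, though, as it does separate the two compounds in the physicochemical assay: the measured solubility of compound 1, 6600 nM, and of compound 3, 20300 nM, a 3.1-fold higher number (0.49 log units; beyond the scatter)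

Among the compounds shown, only formyl and fluoro sit at this position, so how a nitrile or an amine there would fare in the Homo sapiens assay stays open. Also open, from the compounds shown here alone, is whether the step from pyridin-2-yl to 4-fluorophenyl comes from the ring itself or from the fluoro, a question that a plain phenyl group on the same nitrogen would help to settle.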